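The compounds below may be only part of what the source reports. "The series", "measured", "known", "first", "only" and "open" are said of these compounds alone.

Working notes on the series in an assay for inhibition of Nicotinamide phosphoribosyltransferase (Mus musculus), read by fluorescence, with a stated time of 1 h, in the presence of a further agent that is not named here; a higher number here means a weaker inhibitor, a lower number a stronger inhibitor. Compound 1 `O=C(NCCCCCCCn1cc(-c2cccnc2)nn1)c1ccccc1-n1cc(CN2CCC(O)CC2)nn1` gives 41.8 nM in this assay. Compound 2 `CN1CCN(Cc2cn(-c3ccccc3C(=O)NCCCCCCCn3cc(-c4cccnc4)nn3)nn2)CC1` gives 13.6 nM in this assay. For the measured compounds named here, the one measured step, a 3.1-fold lower number from compound 1 to compound 2 (0.49 log units; beyond the scatter), is the exchange of the ring on the saturated chain carbon bound to an aromatic carbon. Going by the values given here, on the two numbers so far compound 2 holds the lower of the two, with compound 1 the nearest, a gap beyond the scatter.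

Compound 3 `CC(C)N1CCN(Cc2cn(-c3ccccc3C(=O)NCCCCCCCn3cc(-c4cccnc4)nn3)nn2)CC1` differs from compound 2 only in isopropyl in place of methyl on an amine nitrogen in a ring. Among the compounds with values here, no measured step touches the substituent on the amine nitrogen in the ring: the step from compound 1 to compound 2 replaced the whole ring, so it does not bear on a change of the group on that ring nitrogen. With nothing in the shown pairs on this position, no step beyond the scatter is expected in either direction, and the estimate for compound 3 stays close to compound 2, a 1.2-fold higher number from compound 2 to compound 3 (0.07 log units; within the scatter). Compound 3 is therefore expected at about 16 nM, within a range of 6 nM to 45 nM.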

Compound 3, half-maximal inhibitory concentration: 24.7 nM
Beside the measured number, compound 3's estimate is 1.5-fold (0.19 log units) below it, and the stated range covers the measured number.
By their numbers in this assay, from the lowest: compounds 2, 3 and 1 (each within the scatter of the next, the first and the last beyond it).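

On the amine nitrogen in the ring, the step from methyl to isopropyl in this assay is a 1.8-fold higher number from compound 2 to compound 3 (0.26 log units; within the scatter) and gives no readable difference, so this position accepts the two added carbons without a step beyond the scatter. This also qualifies the earlier ring exchange: replacing 4-hydroxypiperidin-1-yl with 4-methylpiperazin-1-yl gave a step beyond the scatter, but with 4-isopropylpiperazin-1-yl the step is a 1.7-fold lower number from compound 1 to compound 3 (0.23 log units; within the scatter) and lies within it, so the earlier difference cannot be extended to this piperazine ring with either substituent. No available evidence accounts for either step.

The compounds shown leave open what a piperazine with a hydrogen on that ring nitrogen would give, and whether an acetyl group there would differ from the two alkyl groups. Also open, going by these compounds, is whether a benzyl group, a longer chain or a chain ending in a carboxylic acid on that nitrogen would give a step beyond the scatter, as methyl and isopropyl alone define no trend with group size.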